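Replacing the carbamate on the ring amine with an alkyl group

The source may hold more compounds than are shown below. What is called first, only, known or untested is meant among the compounds shown, and "the series" means these compounds.

Three compounds share one core and differ only in the group attached to the ring amine. Compound 1 `C[C@H](CF)OC(=O)N1CCC(O[C@H]2CC[C@H](Oc3cnc(S(C)(=O)=O)cn3)CC2)CC1`, compound 2 `CS(=O)(=O)c1cnc(O[C@H]2CC[C@H](OC3CCN(C(=O)OC4CCOC4)CC3)CC2)cn1` and compound 3 `CS(=O)(=O)c1cnc(O[C@H]2CC[C@H](OC3CCN(C(=O)Oc4ccccc4)CC3)CC2)cn1` were tested in a functional assay on isolated protein for agonist activity at Glucose-dependent insulinotropic receptor (Rattus norvegicus), read by HTRF and cAMP accumulation; on this read-out lower numbers stand for smaller maximal responses and higher numbers for larger maximal responses. Compound 1 gives 115%, compound 2 gives 109%, and compound 3 gives 104%, the lowest of the three, though close to compound 2. The measured steps are a number 6 percentage points lower from compound 1 to compound 2 (within the scatter), a number 11 percentage points lower from compound 1 to compound 3 (beyond the scatter) and a number 5 percentage points lower from compound 2 to compound 3 (within the scatter). Each of these changes only the group on an oxygen next to a carbonyl group, so the carbamate itself stays in place throughout.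

Compound 4 `CS(=O)(=O)c1cnc(O[C@H]2CC[C@H](OC3CCN(CC4(C(F)(F)F)CC4)CC3)CC2)cn1` goes further: (1-(trifluoromethyl)cyclopropyl)methyl in place of phenoxycarbonyl on an amine nitrogen in a ring. Among the compounds with values here, no measured step touches this part of the molecule, so the three steps give little guidance; what they show is that every group tried so far left the maximal response near or above that of the reference. On that basis compound 4 is expected to give 100%, with a range from 80% to 120%. The step this estimate implies, a number 4 percentage points lower from compound 3 to compound 4 (within the scatter), is expected to stay within the scatter.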

Compound 4, largest response reached (Emax), in percent of the reference or control that the assay uses: 124%
The estimate for compound 4 lay 24 percentage points below the measured number; measured number outside the range, above it.
By their numbers in this assay, from the lowest: compounds 3, 2, 1 and 4 (each within the scatter of the next, the first and the last beyond it).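

In this assay, the carbamate on the amine nitrogen in a ring turns out not to be required for a large maximal response: a group without a carbonyl gives a number 20 percentage points higher from compound 3 to compound 4 (beyond the scatter) and a number 15 percentage points higher from compound 2 to compound 4 (beyond the scatter). The comparison with the remaining carbamate gives a number 9 percentage points higher from compound 1 to compound 4 (within the scatter), so (1-(trifluoromethyl)cyclopropyl)methyl clearly separates from the phenyl and oxolan-3-yl carbamates but not from the carbamate of compound 1. Nothing available explains these steps.

As far as these compounds go, it remains open whether the trifluoromethyl group or the three-membered ring matters more, which a plain cyclopropylmethyl group on the same nitrogen could help to separate. From the compounds shown here alone, how a benzyl group or a simple acetyl amide would behave at this nitrogen also remains open.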